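Trading an Ester for a Methyl on a Shared Core

The source may report more compounds than this note shows. Statements on the series, on what has been measured and on what is new or still open speak of the compounds shown alone.

Of the compounds shown here, three built on one core have been tested in a functional assay on 5637 cells (Homo sapiens) for cytotoxicity, with a stated time of 96 h; on this read-out lower numbers stand for stronger inhibition of growth and higher numbers for weaker inhibition of growth. Compound 1 `COC(=O)c1cc2c(cc1Cl)SC(N(N(C)C)S(=O)(=O)c1ccc(Cl)cc1)=NS2(=O)=O` gives 12600 nM, the highest number of the three. Compound 2 `O=C(Oc1cccc2cccnc12)c1cc2c(cc1Cl)SC(N(c1ccc(F)cc1)S(=O)(=O)c1ccc(Br)s1)=NS2(=O)=O` gives 5100 nM, and compound 3 `O=C(Oc1cccc2cccnc12)c1cc2c(cc1Cl)SC(N(c1ccc(F)cc1)S(=O)(=O)c1ccc(Cl)cc1)=NS2(=O)=O` gives 6200 nM. Compound 3 stands nearest to compound 1 and compound 2 furthest from it, and both gaps lie beyond the scatter. Compound 2 and compound 3 differ from each other only at one sulfonyl sulfur, and that single step is small: a 1.2-fold higher number from compound 2 to compound 3 (0.08 log units; within the scatter).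

Compound 4 `Cc1cc2c(cc1Cl)SC(N(N(C)C)S(=O)(=O)c1ccc(Cl)cc1)=NS2(=O)=O` has not been measured. It differs from compound 1 in one place (methyl in place of methoxycarbonyl on an aromatic carbon). Among the compounds with values here, the only measured step, from compound 2 to compound 3, changes a group on a sulfonyl sulfur in a different pair of compounds, so it says nothing about an exchange at this aromatic carbon. Within the data shown here, there is thus no measured step to lean on, and the expectation rests on compound 1 alone, with a wide range and no firm direction. Compound 4 is therefore expected to give about 15000 nM, within a range from 5000 nM to 45000 nM. That estimate amounts to a 1.2-fold higher number from compound 1 to compound 4 (0.08 log units; within the scatter), a step expected to fall within the scatter.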

Compound 4, concentration for 50% growth inhibition: 19200 nM
Beside the measured number, compound 4's estimate is 1.3-fold (0.11 log units) below it; low and high end bracket the measured number.
By their numbers in this assay, from the lowest: compounds 2 and 3 (each within the scatter of the next); then compounds 1 and 4 (each within the scatter of the next).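

In this assay, the exchange of methoxycarbonyl (4 heavy atoms, 2 hydrogen-bond acceptors) for methyl (1 heavy atom, 0 hydrogen-bond acceptors) on this aromatic carbon, ortho to the chloro group, gives a 1.5-fold higher number from compound 1 to compound 4 (0.18 log units; within the scatter). Within the data shown here, this is the first reading at this position, since the only earlier step concerned a group on a sulfonyl sulfur, and it shows that with the rest of compound 1 held fixed, the carbonyl and both oxygens of the ester can be lost without a change in growth inhibition that stands clear of the usual scatter. No measurement shown here accounts for why this exchange leaves the number within the scatter.

Still open, as far as these compounds go, is whether a group of another kind on this aromatic carbon, such as an amine, a carboxylic acid or a longer chain like n-butyl, would move the number beyond the scatter. Also open, from the compounds shown here alone, is whether methyl in place of the ester would read the same way on the background of compound 3.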